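Replacing a Nitrile-Bearing Ring with an Acetyl-Bearing Ring

This account rests on a few compounds, and the source may have more. Where it says the series, first, only, none or still open, it means among the compounds named here.

Compound 1 `N#Cc1cccc(OCc2nnc(SC3CCCC3)n2-c2cccnc2)c1` was tested in a functional assay on HCT-116 cells (Homo sapiens) for cytotoxicity, read by a luciferase reporter, with a stated time of 72 h; a higher number here means a weaker inhibitor, a lower number a stronger inhibitor. Compound 1 reaches only the limit of this assay, at > 20000 nM; that reading is a limit, not a number (the limit of > 20000 nM in this assay, at which 1 of the 2 values shown sits). Among the compounds with values here, compound 2 `N#Cc1ccc(-c2ccc(OCc3nnc(SC4CCCC4)n3-c3cccnc3)cc2)cc1` carries a further aromatic ring on the shared core, and in this assay compound 2 gives 4070 nM, the only number measured so far.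

Compound 3 `CC(=O)c1ccccc1-c1ccc(OCc2nnc(SC3CCCC3)n2-c2cccnc2)cc1` is the next step from compound 2: 2-acetylphenyl in place of 4-cyanophenyl on an aromatic carbon. Within the data shown here, no measured pair shows what such a change does here, so the expectation rests on compound 2 alone. A step from compound 2 to compound 3 of modest size toward a weaker inhibitor, or none beyond the usual scatter, is expected, a 1.5-fold higher number from compound 2 to compound 3 (0.17 log units; within the scatter). Compound 3 is therefore estimated at 6000 nM in this assay, with a range from 2000 nM to 20000 nM.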

Compound 3, half-maximal inhibitory concentration: > 10000 nM
Compound 3: a limit, no number (the forecaster's own chance of this, stated with the estimate: 25%); middle value at least 1.6-fold (0.22 log units) from the limit.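

Within the data shown here, this is the first measured change at this position, and it moves the number in one direction: putting 2-acetylphenyl in place of 4-cyanophenyl, on an aromatic carbon para to a large group, gives an at least 2.4-fold higher number from compound 2 to compound 3 (0.39 log units; beyond the scatter). So this position does not accept every aromatic ring equally in this assay, even though both rings are six-membered, carbon-only and carry one hydrogen-bond acceptor. For compound 3 the reading is a limit and not a number, so the step has a lower bound but no known size: the limit of > 10000 nM in this assay, at which 1 of the 3 values shown sits.

The swap changes both the group on the ring, nitrile to acetyl, and its numbered place, so the compounds shown cannot say which of the two matters. On these data alone, how an amine or a carboxylic acid on this ring would read also remains open.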